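Swapping a hydroxy for a vinyl on the picolinamide-like core

The compounds below may be only part of what the source reports. "The series", "measured", "known", "first", "only" and "open" are said of these compounds alone.

This short series asks how much of each compound cells will tolerate before they die. The measure is an ADME assay on MDCK cells (Canis lupus familiaris) for cytotoxicity, read by CellTiter-Glo, with a stated time of 10 min; a lower number here means that less compound is tolerated, a higher number that more compound is tolerated. Compound 1, with structure `NC(=O)c1nccc([C@@H]2O[C@H](CO)[C@@H](O)[C@H]2O)c1O`, is the least tolerated of the two compounds that give a number: in this assay compound 1 gives 2000 nM. Compound 2, with structure `NC(=O)c1nccc([C@@H]2O[C@H](CO)[C@@H](O)[C@H]2F)c1F`, gives 306000 nM in this assay, a much higher number. Compound 3, with structure `NC(=O)c1nccc([C@@H]2O[C@H](CO)[C@@H](O)[C@H]2O)n1`, reaches only the limit of the assay, > 200000 nM, so no number is known for it; the evidence here is the limit of > 200000 nM in this assay, at which 1 of the 3 values shown sits.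

The next compound is compound 4, with structure `C=Cc1c([C@@H]2O[C@H](CO)[C@@H](O)[C@H]2O)ccnc1C(N)=O`. It differs from compound 1 in one place: vinyl in place of hydroxy on an aromatic carbon. Both compound 2 and compound 3 lack the hydroxy that compound 1 carries on the aromatic ring, and both are tolerated far more, so the step from compound 1 to compound 4 is expected to be a large rise in the number, well beyond the scatter, a 50-fold higher number from compound 1 to compound 4 (1.70 log units; beyond the scatter). Compound 4 is therefore estimated at 100000 nM, likely between 20000 nM and 300000 nM, with a fair chance that this assay reports only a limit.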

Compound 4, half-maximal cytotoxic concentration: 152000 nM
The estimate for compound 4 lay 1.5-fold (0.18 log units) below the measured number; measured number inside the range.
By their numbers in this assay, from the lowest: compound 1; then compounds 4 and 2 (each within the scatter of the next).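

Replacing the hydroxy with a vinyl on this aromatic carbon, ortho to a carbamoyl group, gives a 76-fold higher number from compound 1 to compound 4 (1.88 log units; beyond the scatter) in this assay. For the compounds shown here, this is the first comparison that changes only one place, so the low number of compound 1 can now be tied to this position, with the rest of the structure held constant. The hydroxy counts one hydrogen-bond donor and one acceptor and the vinyl counts neither, but nothing measured here shows why the number rises.

Going by these compounds, what remains open is whether the rise comes from losing the hydroxy or from gaining the vinyl, which a plain hydrogen, a methoxy or an ethyl at this position could help to separate. It is also unknown how an amine, a carboxylic acid or a longer chain would behave there.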